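The compounds below may be only part of what the source reports. "The series", "measured", "known", "first", "only" and "open" are said of these compounds alone.

Measured compounds:
compound 1 `O=C(Nc1cccc(-n2cc(-c3ccncc3)c(-c3ccc(Cl)c(O)c3)n2)c1)Nc1ccc(Cl)c(Cl)c1`: > 32500 nM
compound 2 `COc1cc(-c2nn(-c3cccc(NC(=O)c4ccc(Cl)c(C(F)(F)F)c4)c3)cc2-c2ccncc2)ccc1Cl`: > 32500 nM

Of the compounds shown here, two have so far been tested in a functional assay on MOLT-4 cells (Homo sapiens) for inhibition, read by sulforhodamine B assay, with a stated time of 48 h; on this read-out higher numbers stand for weaker inhibition of growth and lower numbers for stronger inhibition of growth. In this assay compound 1 returned only a limit, > 32500 nM. In this assay compound 2 also returned only a limit, > 32500 nM. Compound 2 therefore stands exactly where every value shown stands: the limit of > 32500 nM in this assay, at which 2 of the 2 values shown sit. Within the data shown here, neither compound gives a number, so no step between measured compounds can be read. Nothing tells how far past the limit either of them lies.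

The next compound, compound 3 `COc1cc(-c2nn(-c3cccc(NC(=O)c4cccc(C(F)(F)F)c4)c3)cc2-c2ccncc2)ccc1Cl`, is the counterpart of compound 2 with a single change: hydrogen in place of chloro on an aromatic carbon. Among the measured compounds shown here, no measured step speaks for or against this change, and the only anchor is a limit. The expected step from compound 2 to compound 3 is a step that the limit leaves unreadable from compound 2 to compound 3, which amounts to nothing beyond the usual scatter, with the most likely outcome being another limit. The estimate for compound 3 in this assay is 40000 nM, with a range from 12000 nM to 120000 nM.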

Compound 3, concentration for total growth inhibition: > 50000 nM
Compound 3: no number, only a limit; the forecaster's own chance of this, stated with the estimate: 75%; at least 1.2-fold (0.09 log units) between middle value and limit.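

Compound 2 and compound 3 both returned only limits, so no step can be read for hydrogen in place of chloro on the aromatic carbon. The compounds shown leave open how far past its limit each one lies, and whether any compound of this kind gives a number in this assay.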